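Aryl swap on the pyrazole nitrogen of a urea antagonist

This account rests on a few compounds, and the source may have more. Where it says the series, first, only, none or still open, it means among the compounds named here.

Measured compounds:
compound 1, `Cn1ncc2c(NC(=O)NCc3cc(C(F)(F)F)nn3-c3cccc(C(F)(F)F)c3)cccc21`, 1.4 nM
compound 2, `Cn1ncc2c(NC(=O)NCc3cc(C(C)(C)C)nn3-c3cccc(C(F)(F)F)c3)cccc21`, 0.6 nM

Both compounds were tested in an assay on CHO-K1 cells for antagonist activity at transient receptor potential cation channel subfamily V member 1 (Homo sapiens), read by FLIPR and calcium flux, with a stated time of 6 min; on this read-out higher numbers stand for weaker inhibition and lower numbers for stronger inhibition. Going by the values given here, compound 2 gives the lowest of the two numbers, and its only neighbour is compound 1, whose number lies a 2.3-fold lower number from compound 1 to compound 2 (0.37 log units; beyond the scatter); this one step, tert-butyl in place of trifluoromethyl on an aromatic carbon, is modest but beyond the scatter.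

Compound 3, `Cn1ncc2c(NC(=O)NCc3cc(C(C)(C)C)nn3-c3ccc(F)c(Cl)c3)cccc21`, has not yet been measured. It differs from compound 2 in one place: 3-chloro-4-fluorophenyl in place of 3-(trifluoromethyl)phenyl on an aromatic nitrogen. Among the compounds with values here, the one measured step concerns the substituent on the five-membered ring carbon, not the aryl group on the ring nitrogen, so no measured step bears directly on the change from compound 2 to compound 3. The tert-butyl that accompanies the lower number of compound 2 is kept in compound 3. Within the data shown here, with no guiding step, the expectation for this assay is a step of a 1.7-fold higher number from compound 2 to compound 3 (0.22 log units; within the scatter), most likely within the scatter in either direction. Compound 3 is therefore estimated at 1 nM, with a range from 0.3 nM to 4 nM.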

Compound 3, inhibition constant: 0.6 nM
The estimate for compound 3 lay 1.7-fold (0.22 log units) above the measured number, within the range that was stated.
By their numbers in this assay, from the lowest: compounds 2 and 3 (each within the scatter of the next); then compound 1.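

Up to this point only the group on the ring carbon had changed. Here the group on the aromatic nitrogen changes for the first time, and in this assay the step to 3-chloro-4-fluorophenyl in place of 3-(trifluoromethyl)phenyl gives no change at the digits printed from compound 2 to compound 3 (within the scatter), with the tert-butyl group kept. At this position, in this pair, a trifluoromethyl group on the phenyl ring is therefore not required for a number of this size, as a chlorine and a fluorine on the ring serve in its place with no change beyond the scatter. Nothing measured here bears on why the two aryl groups read alike.

The compounds shown leave open whether the two aryl groups would also read alike with trifluoromethyl instead of tert-butyl on the ring carbon, the arrangement found in compound 1. They also leave open how this position would respond to an unsubstituted phenyl, a pyridine ring, or a phenyl ring carrying an amine or a carboxylic acid.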